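Replacing hydroxyethyl by an oxazolyl ring on the amide nitrogen

The source may report more compounds than this note shows. Statements on the series, on what has been measured and on what is new or still open speak of the compounds shown alone.

Compound 1, `Cc1ccc(OCC(=O)N(Cc2cccs2)c2ccnn2C)cc1`: 422 nM
Compound 2, `Cc1ccc(OCC(=O)N(Cc2cccs2)C(C)C)cc1`: 70 nM
Compound 3, `Cc1ccc(OCC(=O)N(CCO)Cc2cccs2)cc1`: 900 nM

In an assay on HEK293 cells for agonist activity at transient receptor potential cation channel subfamily M member 8 (Homo sapiens), read by fluorescence and calcium flux, with a stated time of 15 min (on this read-out higher numbers stand for an effect only at larger amounts of compound and lower numbers for an effect already at smaller amounts), compound 3 gives the highest of the three numbers. Its nearest neighbour is compound 1, and the step between them is a 2.1-fold higher number from compound 1 to compound 3 (0.33 log units; beyond the scatter); its furthest is compound 2, with the step of a 13-fold higher number from compound 2 to compound 3 (1.11 log units; beyond the scatter). Compound 4, `Cc1ccc(OCC(=O)N(Cc2cccs2)c2ccon2)cc1`, differs from compound 3 in one place: 1,2-oxazol-3-yl in place of 2-hydroxyethyl on an amide-type nitrogen. For the measured compounds named here, the step that bears most directly on this change is the one from compound 1 to compound 3, a 2.1-fold higher number from compound 1 to compound 3 (0.33 log units; beyond the scatter), where a five-membered aromatic ring on the same nitrogen went with a lower number than the 2-hydroxyethyl group. The step of a 6.0-fold lower number from compound 1 to compound 2 (0.78 log units; beyond the scatter) shows isopropyl lower still, but that group plays no part in compound 4. A modest downward step in this assay is therefore expected for compound 4, a 2.0-fold lower number from compound 3 to compound 4 (0.30 log units; within the scatter). Compound 4 is estimated at 450 nM, with a range from 150 nM to 1400 nM.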

Compound 4, half-maximal effective concentration: 2 nM
Compound 4: the middle estimate sits 230-fold (2.35 log units) above what was measured, outside the stated range (below it).
By their numbers in this assay, from the lowest: compound 4; then compound 2; then compound 1; then compound 3.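

In this assay, for the compounds shown here, the amide-type nitrogen proves far more sensitive to the identity of its five-membered aromatic ring than the earlier compounds showed: 1,2-oxazol-3-yl in place of 1-methyl-1H-pyrazol-5-yl gives a 210-fold lower number from compound 1 to compound 4 (2.32 log units; beyond the scatter) and so having such a ring at this place does not by itself set the number. Going by these compounds alone, the same ring in place of 2-hydroxyethyl gives a 450-fold lower number from compound 3 to compound 4 (2.65 log units; beyond the scatter) and it also goes past isopropyl, the lowest number among the earlier compounds, with a 35-fold lower number from compound 2 to compound 4 (1.54 log units; beyond the scatter) as the step. Compound 4 therefore has the lowest number of the four, and every step to it lies beyond the scatter.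

No measurement given here accounts for the gap between the two rings. The compounds shown leave open whether a 1,3-oxazol-2-yl ring, a 1,2-oxazol-5-yl ring or a plain phenyl ring on this nitrogen would give a number as low as that of compound 4.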